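Urea series: heteroaryl swap on the six-membered ring

The compounds below may be only part of what the source reports. "The series", "measured", "known", "first", "only" and "open" are said of these compounds alone.

The shared core is varied at the aryl on the amide-type nitrogen and at the group on an aromatic carbon of the six-membered aromatic ring of carbon only. In an assay on microsomes from intestine for inhibition of acyl-CoA:cholesterol acyltransferase (Oryctolagus cuniculus) (on this read-out lower numbers stand for stronger inhibition and higher numbers for weaker inhibition), compound 1 `O=C(Nc1c(F)cc(F)cc1F)N(Cc1cccc(-c2cc[nH]n2)c1)C1CCCCCC1` gives 22 nM. Compound 2 `O=C(Nc1c(F)cc(F)cc1F)N(Cc1ccc(-c2ccsc2)cc1)C1CCCCCC1` gives 23 nM. Compound 3 `Cc1cc(C)c(NC(=O)N(Cc2ccc(-c3ccsc3)cc2)C2CCCCCC2)c(C)c1` gives 19 nM. All three lie within the scatter of one another, compound 3 sitting at the low end. For the measured compounds named here, the one measured step, a 1.2-fold lower number from compound 2 to compound 3 (0.08 log units; within the scatter), concerns the aryl on the amide-type nitrogen and does not bear on the next change. Compound 4 `Cc1cc(C)c(NC(=O)N(Cc2ccc(-c3cnn(C)c3)cc2)C2CCCCCC2)c(C)c1` differs from compound 3 by 1-methyl-1H-pyrazol-4-yl in place of thiophen-3-yl on an aromatic carbon. Compounds 1 and 2, which carry the two heteroaryls but differ in more than one place, show values within the scatter of each other, so a step no larger than the scatter is expected, a 1.2-fold higher number from compound 3 to compound 4 (0.06 log units; within the scatter). Compound 4 is therefore estimated at 22 nM, ranging from 9 nM to 55 nM.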

Compound 4, half-maximal inhibitory concentration: 47 nM
Estimate against measurement, compound 4: 2.1-fold (0.33 log units) below; the measured number falls inside the stated range.
By their numbers in this assay, from the lowest: compounds 3, 1 and 2 (each within the scatter of the next); then compound 4.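

In this assay, for the compounds shown here, a 2.5-fold higher number from compound 3 to compound 4 (0.39 log units; beyond the scatter) is the only step at this position, on an aromatic carbon para to a large group, and it lies beyond the scatter. With the 2,4,6-trimethylphenyl held fixed, the position therefore does not treat thiophen-3-yl and 1-methyl-1H-pyrazol-4-yl alike, although the step is modest. No available evidence bears on this difference.

As far as these compounds go, it remains open whether 1H-pyrazol-4-yl without the methyl, or a plain phenyl, would fall nearer compound 3 or compound 4. From the compounds shown here alone, the same swap on the 2,4,6-trifluorophenyl urea also remains open.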